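From compound 3 to compound 4 at the amide nitrogen

A few compounds are considered here, and "the series" means these few. Any claim that something is new, unique, unknown or untested is made for them only; others in the source may bear on it.

In a functional assay on Caco-2 cells (Homo sapiens) for antiproliferative activity, read by MTT assay, with a stated time of 48 h (on this read-out lower numbers stand for stronger inhibition and higher numbers for weaker inhibition), compound 1 (`CCn1c(C(=O)NCCN(C)C)ccc1C(CC)(CC)c1ccc(OCCC(O)(CC)CC)c(C)c1`) gives 1140 nM and compound 2 (`CCn1c(C(=O)NCCN)ccc1C(CC)(CC)c1ccc(OCCC(O)(CC)CC)c(C)c1`) gives 1740 nM, with a 1.5-fold higher number from compound 1 to compound 2 (0.18 log units; within the scatter) between them. Compound 3 (`CCn1c(C(=O)Nc2cccc(C(F)(F)F)c2)ccc1C(CC)(CC)c1ccc(OCCC(O)(CC)CC)c(C)c1`) gives only a limit (> 50000 nM) and no number. Compound 4 (`CCC(C)C(NC(=O)c1ccc(C(CC)(CC)c2ccc(OCCC(O)(CC)CC)c(C)c2)n1CC)C(=O)O`) has 1-carboxy-2-methylbutyl in place of 3-(trifluoromethyl)phenyl on an amide-type nitrogen. The measured steps of an at least 43-fold higher number from compound 1 to compound 3 (1.64 log units; beyond the scatter) and an at least 28-fold higher number from compound 2 to compound 3 (1.45 log units; beyond the scatter) are both large and fall at that place, so removing 3-(trifluoromethyl)phenyl is expected to lower the number, though by less, as neither compound 1 nor compound 2 carries a carboxy group. The expected step is an at least 6.2-fold lower number from compound 3 to compound 4 (0.79 log units; beyond the scatter) in this assay as a working figure. For compound 4 the estimated value is 8000 nM with an expected range from 1500 nM to 40000 nM in this series.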

Compound 4, half-maximal inhibitory concentration: 20000 nM
Estimate against measurement, compound 4: 2.5-fold (0.40 log units) below, and the stated range covers the measured number.
By their numbers in this assay, from the lowest: compounds 1 and 2 (each within the scatter of the next); then compound 4. At a limit, above all of these: compound 3.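

In this assay, a carboxy-bearing chain on the amide nitrogen gives a measurable number where 3-(trifluoromethyl)phenyl does not, with an at least 2.5-fold lower number from compound 3 to compound 4 (0.39 log units; beyond the scatter). Compound 3 gives only a limit: the limit of > 50000 nM in this assay, at which 1 of the 4 values shown sits. Even so, 1-carboxy-2-methylbutyl falls well short of both amine-bearing chains, with an 11-fold higher number from compound 2 to compound 4 (1.06 log units; beyond the scatter) and an 18-fold higher number from compound 1 to compound 4 (1.24 log units; beyond the scatter).

Open, as far as these compounds go, is whether the carboxylic acid or the branched chain accounts for these steps, which a 2-methylbutyl group without the acid would separate. Also open, from the compounds shown here alone, is how a longer amine chain would read here.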